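The compounds below may be only part of what the source reports. "The series", "measured", "known", "first", "only" and "open" are said of these compounds alone.

In a functional assay on PC-3 cells (Homo sapiens) for cytotoxicity (on this read-out higher numbers stand for weaker inhibition and lower numbers for stronger inhibition), compound 1 `COC(=O)C1C(c2oc(=O)c(CO)c(OC)c2CO)C(C(=O)OC)C1c1oc(=O)c(CO)c(OC)c1CO` reads > 50000 nM as a limit. Compound 2 `COc1c(C)c(/C=C/C(=O)O)oc(=O)c1CO` reads > 50000 nM as a limit, so it offers no number to start from. Compound 3 `COc1c(CO)c(/C=C/C(=O)O)oc(=O)c1CO` reads > 50000 nM as a limit too. For the measured compounds named here, the series so far sits at the limit of > 50000 nM in this assay, at which 3 of the 3 values shown sit, without exception. Compound 4 `COc1c(C)c(/C=C/C(=O)O)oc(=O)c1C` differs from compound 2 by hydrogen in place of hydroxy on a saturated chain carbon bound to an aromatic carbon in the change from hydroxymethyl to methyl. Going by the values given here, the only measured step of this kind is a step that the two limits leave unreadable from compound 2 to compound 3 and it runs the other way, so no size carries over and no step beyond the scatter is expected in this assay in either direction. The expected outcome is a number no higher from compound 2 to compound 4 (the limit leaves the size open) by this estimate. For compound 4 the estimated value is 50000 nM within a range of 20000 nM to 100000 nM and most likely again a limit.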

Compound 4, half-maximal inhibitory concentration: > 50000 nM
Compound 4: no number, only a limit; the forecaster's own chance of this, stated with the estimate: 80%; the middle value lies on the limit itself.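

No step can be read from compound 2 to compound 4, since both give only a limit: the limit of > 50000 nM in this assay, at which 4 of the 4 values shown sit. The compounds shown leave open which change to the shared core, if any, would yield a readable number in this assay.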